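Shifting a Methoxyphenyl Group on Two Related Cores

The source may hold more compounds than are shown below. What is called first, only, known or untested is meant among the compounds shown, and "the series" means these compounds.

Three compounds have been tested in a functional assay on SK-BR-3 cells (Homo sapiens) for antiproliferative activity; a lower number here means a stronger inhibitor, a higher number a weaker inhibitor:

compound 1 `COc1ccc(Oc2ccc3cc(NC(=O)c4ccc(O)c(CC=C(C)C)c4)c(=O)oc3c2C)cc1`, giving 42700 nM
compound 2 `COc1cccc(Oc2ccc3cc(NC(=O)c4ccc(O)c(CC=C(C)C)c4)c(=O)oc3c2C)c1`, giving 33100 nM
compound 3 `COc1ccc(Oc2ccc3cc(NC(=O)c4ccc(OC)c(-c5cccc(OC)c5)c4)c(=O)oc3c2C)cc1`, for which only a limit is known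

Compound 1 and compound 2 share a core and differ by 3-methoxyphenyl in place of 4-methoxyphenyl on an oxygen on an aromatic ring. That change made a 1.3-fold lower number from compound 1 to compound 2 (0.11 log units; within the scatter), so the two compounds cannot be told apart in this assay. Compound 3 carries a different core; the difference between the core of compound 1 and the core of compound 3 is not broken down here. In this assay compound 3 gives only a limit of the assay, > 100000 nM, and no number.

Compound 4 `COc1cccc(Oc2ccc3cc(NC(=O)c4ccc(OC)c(-c5cccc(OC)c5)c4)c(=O)oc3c2C)c1` has not yet been measured. It differs from compound 3 by 3-methoxyphenyl in place of 4-methoxyphenyl on an oxygen on an aromatic ring, the same change as between compound 1 and compound 2. Because that change made a 1.3-fold lower number from compound 1 to compound 2 (0.11 log units; within the scatter), a step of similar size is expected from compound 3 to compound 4, namely a step that the limit leaves unreadable from compound 3 to compound 4. Compound 4 is therefore expected to sit around 110000 nM in this assay, quite possibly again only as a limit, within an estimated range from 40000 nM to 300000 nM.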

Compound 4, half-maximal inhibitory concentration: > 100000 nM
Compound 4: only a limit was reported; the forecaster's own chance of this, stated with the estimate: 80%; the middle value lies beyond the limit too.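

In this assay compound 4 gives > 100000 nM, a limit of the assay and not a number. Compound 3 and compound 4 both stop at this limit, so no step between them can be read: the limit of > 100000 nM in this assay, at which 2 of the 4 values shown sit.

The compounds shown leave open whether 3-methoxyphenyl in place of 4-methoxyphenyl changes the activity at all on the core of compound 3.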